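Swapping a Trifluoromethyl Sulfonyl for a Phenyl Sulfonyl

The source may hold more compounds than are shown below. What is called first, only, known or untested is meant among the compounds shown, and "the series" means these compounds.

Measured in a physicochemical assay for lipophilicity; a higher number here means a more lipophilic compound, a lower number a more polar compound:
Compound 1 `CCN(CCn1cc[n+](C)c1/C=N/O)S(=O)(=O)C(F)(F)F` gives -1.03.
Compound 2 `CCCN(CCn1cc[n+](C)c1/C=N/O)S(=O)(=O)C(F)(F)F` gives -0.69.
Compound 3 `C[n+]1ccn(CCN(Cc2ccccc2)S(=O)(=O)C(F)(F)F)c1/C=N/O` gives -0.01.

Compound 2 stands second highest of these three: a number 0.34 log units higher from compound 1 to compound 2 (beyond the scatter), while a number 0.68 log units higher from compound 2 to compound 3 (beyond the scatter). Compound 4 `CCCN(CCn1cc[n+](C)c1/C=N/O)S(=O)(=O)c1ccccc1` differs from compound 2 by phenyl in place of trifluoromethyl on a sulfonyl sulfur. Going by the values given here, no measured step alters the sulfonyl group itself, but two steps place a phenyl where a small alkyl group stood on a chain carbon: a number 1.02 log units higher from compound 1 to compound 3 (beyond the scatter) and a number 0.68 log units higher from compound 2 to compound 3 (beyond the scatter). Both moved the reading upward, one large and one modest. A rise of comparable size is therefore expected here, the step from compound 2 to compound 4 being estimated at a number 0.59 log units higher from compound 2 to compound 4 (beyond the scatter). Compound 4 is accordingly expected to come out near -0.1, within a range from -0.6 to 0.4.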

Compound 4, distribution coefficient: -0.94
Beside the measured number, compound 4's estimate is 0.84 log units above it; measured number outside the range, below it.
By their numbers in this assay, from the lowest: compounds 1, 4 and 2 (each within the scatter of the next, the first and the last beyond it); then compound 3.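

On the sulfonyl sulfur, phenyl in place of trifluoromethyl gives a number 0.25 log units lower from compound 2 to compound 4 (within the scatter) in this assay and so cannot be told apart from it here. On a saturated chain carbon bound to a sulfonamide nitrogen, phenyl in place of ethyl gave a number 0.68 log units higher from compound 2 to compound 3 (beyond the scatter) instead, so what phenyl did at that place does not carry over to the sulfonyl sulfur. Nothing available accounts for this contrast.

As far as these compounds go, whether an amine or a longer alkyl chain on the sulfonyl sulfur would also stay within the scatter remains open. So does whether this swap behaves alike in compound 1 and compound 3.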